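The source may hold more compounds than are shown below. What is called first, only, known or untested is meant among the compounds shown, and "the series" means these compounds.

Among the compounds with values here, compound 2 `O=C(/C=C/c1ccccc1)OCCc1c(-c2ccccc2Cl)c2cc(Cl)ccc2[nH]c1=O` gives the highest of the two numbers so far in an ADME assay on HepG2 2.2.15 cells (Homo sapiens) for cytotoxicity (on this read-out lower numbers stand for higher toxicity in this test and higher numbers for lower toxicity in this test), namely 230000 nM; its nearest neighbour is compound 1 `O=C(OCCc1c(-c2ccccc2Cl)c2cc(Cl)ccc2[nH]c1=O)C1CCCC1`, which in this assay gives 46000 nM. Within the data shown here, that neighbour differs from compound 2 in one place, and the step of a 5.0-fold higher number from compound 1 to compound 2 (0.70 log units; beyond the scatter) is the only measured change at the carbonyl carbon of the ester. Compound 3 `C/C=C(\C)C(=O)OCCc1c(-c2ccccc2Cl)c2cc(Cl)ccc2[nH]c1=O` is not yet measured. It differs from compound 2 as follows: 1-methylprop-1-en-1-yl in place of 2-phenylethenyl on a carbonyl carbon. The entering group is smaller than the leaving one and, like the cyclopentyl of compound 1, carries no aromatic ring, so the measured step gives only loose guidance. Compound 3 is therefore expected to give in this assay a number somewhat below that of compound 2, with the step of a 2.3-fold lower number from compound 2 to compound 3 (0.36 log units; beyond the scatter) estimated as modest, around 100000 nM and likely between 35000 nM and 300000 nM.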

Compound 3, half-maximal cytotoxic concentration: 350000 nM
For compound 3 the middle estimate is 3.5-fold (0.54 log units) below the measured one; measured number outside the range, above it.
By their numbers in this assay, from the lowest: compound 1; then compounds 2 and 3 (each within the scatter of the next).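

In this assay, the step of a 1.5-fold higher number from compound 2 to compound 3 (0.18 log units; within the scatter) shows that the ring-free 1-methylprop-1-en-1-yl group and the 2-phenylethenyl group cannot be told apart on the carbonyl carbon. The six-membered aromatic ring of the 2-phenylethenyl group is therefore not required for a number of this size. The step of a 7.6-fold higher number from compound 1 to compound 3 (0.88 log units; beyond the scatter) adds a second group that stands clear of cyclopentyl, so among these three compounds the two groups with a double bond outside aromatic rings give higher numbers than cyclopentyl, and no compound shown goes against this.

Three compounds cannot show whether the double bond itself matters, as a saturated open chain such as butyl is not among them. From the compounds shown here alone, it also stays open how an amine or a carboxylic acid at this carbon would read. No evidence is available that explains these numbers.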